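Replacing the 4-azidophenyl group of compound 3

The source may report more compounds than this note shows. Statements on the series, on what has been measured and on what is new or still open speak of the compounds shown alone.

In an ADME assay on NCI-H460 cells (Homo sapiens) for cytotoxicity, read by MTT assay, with a stated time of 72 h (on this read-out lower numbers stand for stronger inhibition and higher numbers for weaker inhibition), compound 2 `CCCc1ccc(C(=O)Nc2ccccc2-c2nnn(-c3cccc(OC)c3)n2)cc1` gives 27000 nM. Compound 3 `COc1cccc(-n2nnc(-c3ccccc3NC(=O)c3ccc(N=[N+]=[N-])cc3)n2)c1` gives 20300 nM, and the two cannot be told apart, as the measured step shows: a 1.3-fold lower number from compound 2 to compound 3 (0.12 log units; within the scatter). Compound 1 `COc1ccc(C(=O)Nc2ccccc2-c2nnn(-c3ccc(OC)cc3)n2)cc1` returns only a limit, > 100000 nM. Among the compounds with values here, compound 3 therefore stands within the scatter of compound 2, the one other compound with a true number.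

Compound 4 `COc1cccc(-n2nnc(-c3ccccc3NC(=O)Nc3ccc(N)cc3)n2)c1` differs from compound 3 in one place: (4-aminophenyl)amino in place of 4-azidophenyl on a carbonyl carbon. Within the data shown here, only one measured step is available as a guide, and it swaps azido for propyl on an aromatic carbon, not a group on the carbonyl carbon. That step, a 1.3-fold lower number from compound 2 to compound 3 (0.12 log units; within the scatter), therefore offers weak guidance. Among the measured compounds shown here, no measured step covers the carbonyl carbon, so no shift beyond the scatter is expected, though with wide uncertainty. The expected change is a 1.2-fold higher number from compound 3 to compound 4 (0.09 log units; within the scatter). The estimate for compound 4 is 25000 nM, with an expected range of 8000 nM to 80000 nM.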

Compound 4, half-maximal inhibitory concentration: > 100000 nM
Compound 4: only a limit was reported (the forecaster's own chance of this, stated with the estimate: 15%); at least 4.0-fold (0.60 log units) between middle value and limit.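

Unlike the swap of azido for propyl, which stayed within the scatter, the change on the carbonyl carbon shows up clearly in this assay: an at least 4.9-fold higher number from compound 3 to compound 4 (0.69 log units; beyond the scatter), and an at least 3.7-fold higher number from compound 2 to compound 4 (0.56 log units; beyond the scatter). This position is therefore not indifferent to what it carries: 4-azidophenyl and 4-propylphenyl give values within the scatter of each other, while (4-aminophenyl)amino gives weaker inhibition than either. Compound 4 returns only a limit, so both steps are minimum sizes, and that same limit recurs in this small set: the limit of > 100000 nM in this assay, at which 2 of the 4 values shown sit.

The amino group on the ring and the nitrogen on the carbonyl carbon enter together, and the compounds shown cannot separate their contributions. A 4-aminophenyl group attached directly to the carbonyl carbon would be needed to tell them apart.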